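Replacing benzothiophene with fluoroindane on the sulfonamide nitrogen

The source may report more compounds than this note shows. Statements on the series, on what has been measured and on what is new or still open speak of the compounds shown alone.

Of the compounds shown here, three sharing one core have been measured in a physicochemical assay for lipophilicity, at pH 7.4; on this read-out lower numbers stand for lower lipophilicity and higher numbers for higher lipophilicity. Compound 1 `CC(C)CN(Cc1ccccc1C(F)(F)F)S(=O)(=O)c1ccc2c(c1)C(=O)CC(C1CCOCC1)O2` gives 4.32, compound 2 `CC(C)CN(c1cccc(F)c1)S(=O)(=O)c1ccc2c(c1)C(=O)CC(C1CCOCC1)O2` gives 3.5, and compound 3 `CC(C)CN(c1cc2ccccc2s1)S(=O)(=O)c1ccc2c(c1)C(=O)CC(C1CCOCC1)O2` gives 4.01. Compound 3 therefore stands second highest of the three, separated from both neighbours beyond the scatter: a number 0.31 log units lower from compound 1 to compound 3 (beyond the scatter) and a number 0.51 log units higher from compound 2 to compound 3 (beyond the scatter). Compound 4 `CC(C)CN(C1CCc2ccc(F)cc21)S(=O)(=O)c1ccc2c(c1)C(=O)CC(C1CCOCC1)O2` is not yet measured; it differs from compound 3 by 6-fluoro-2,3-dihydro-1H-inden-1-yl in place of 1-benzothiophen-2-yl on a sulfonamide nitrogen. The measured steps at this position all change an aryl or benzyl group for another and are all modest in size, so the expected shift for a number 0.19 log units higher from compound 3 to compound 4 (within the scatter) is small and slightly upward, leaning on compound 1 with 4.32 for a benzyl-type nitrogen substituent. Compound 4 is estimated at 4.2, within 3.8 to 4.6.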

Compound 4, distribution coefficient: 4.03
Beside the measured number, compound 4's estimate is 0.17 log units above it, within the range that was stated.
By their numbers in this assay, from the lowest: compound 2; then compounds 3, 4 and 1 (each within the scatter of the next, the first and the last beyond it).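

In this assay, putting 6-fluoro-2,3-dihydro-1H-inden-1-yl in place of 1-benzothiophen-2-yl on the sulfonamide nitrogen gives a number 0.02 log units higher from compound 3 to compound 4 (within the scatter), so at this position a five-membered non-aromatic ring of carbon only, with fluorine in the group, cannot be told from a five-membered aromatic ring with sulfur. The same group gives a number 0.53 log units higher from compound 2 to compound 4 (beyond the scatter) and a number 0.29 log units lower from compound 1 to compound 4 (within the scatter), so compound 4 is separated beyond the scatter only from compound 2. Nothing measured here bears on the reason for these steps.

As far as these compounds go, what 2,3-dihydro-1H-inden-1-yl would read without its fluorine stays open. So does the reading of a group carrying an amine or a carboxylic acid on this nitrogen.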